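Stilbene sulfonamides: demethylating the methoxy of compound 2

This account rests on a few compounds, and the source may have more. Where it says the series, first, only, none or still open, it means among the compounds named here.

Within the data shown here, compound 2 `COc1cccc(/C=C/c2ccc(S(N)(=O)=O)cc2)c1` gives the lowest number among the three compounds measured so far in a functional assay on U-251 cells (Homo sapiens) for inhibition (a lower number here means a stronger inhibitor of growth, a higher number a weaker inhibitor of growth), at 5540 nM. Its nearest neighbour is compound 3 `NS(=O)(=O)c1ccc(/C=C/c2ccc(O)cc2)cc1`, which in this assay gives 15000 nM; the furthest is compound 1 `COc1cc(/C=C/c2ccc(S(N)(=O)=O)cc2)cc(OC)c1`, which in this assay gives 17100 nM. Among the measured compounds shown here, the one single-point step measured so far is a 3.1-fold lower number from compound 1 to compound 2 (0.49 log units; beyond the scatter), a modest gain on removing one methoxy.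

Compound 4 `NS(=O)(=O)c1ccc(/C=C/c2cccc(O)c2)cc1` is not yet measured. It differs from compound 2 by hydrogen in place of methyl on an oxygen on an aromatic ring. For the measured compounds named here, no measured step covers this exact change: compound 2 and compound 3 differ both in the group and in its place on the ring, so their two values can only be set side by side, and compound 3 gives the higher number. The step from compound 1 to compound 2 concerns a whole methoxy, not its methyl alone, and so bears only loosely here.

On that basis compound 4 is expected to give a number near that of compound 2 or somewhat higher, with a step of a 1.4-fold higher number from compound 2 to compound 4 (0.16 log units; within the scatter) that may stay within the scatter. The estimate for compound 4 in this assay is 8000 nM, within a range of 2500 nM to 25000 nM.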

Compound 4, concentration for 50% growth inhibition: 21100 nM
The estimate for compound 4 lay 2.6-fold (0.42 log units) below the measured number; the measured number falls inside the stated range.
By their numbers in this assay, from the lowest: compound 2; then compounds 3, 1 and 4 (each within the scatter of the next).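

In this assay, among these compounds, the methyl on the oxygen is the first single group tested alone at this place, and removing it costs growth inhibition: a 3.8-fold higher number from compound 2 to compound 4 (0.58 log units; beyond the scatter), a modest but real loss on going from methoxy to hydroxy. The step of a 3.1-fold lower number from compound 1 to compound 2 (0.49 log units; beyond the scatter) concerned a whole methoxy and ran the opposite way, so among these compounds a lower number does not simply follow from stripping atoms off the methoxy-bearing ring, and compound 2 remains the lowest of the four. No measurement given here explains why the free hydroxy gives the higher number in this pair.

How far this applies beyond the one place is open, since compound 3 carries its hydroxy elsewhere on the ring and differs from compound 2 in both group and place. Also open, as far as these compounds go, is whether an ethoxy group, a longer alkoxy chain, an amine or a carboxylic acid at the place of the methoxy would give a lower number than compound 2, which stands at 5540 nM, or whether the methoxy is the best of such groups.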